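The source may report more compounds than this note shows. Statements on the series, on what has been measured and on what is new or still open speak of the compounds shown alone.

In a functional assay on the whole organism for inhibition, with Cavia porcellus as the target (on this read-out higher numbers stand for an effect only at larger amounts of compound and lower numbers for an effect already at smaller amounts), compound 1 (`COC(=O)c1ccc(OCC2SCCN2C(=O)Cn2ccnc2)cc1`) gives 62 mg/kg and compound 2 (`COc1ccccc1OCC1SCCN1C(C)=O`) gives 46 mg/kg within the scatter of each other. Compound 3 (`CCOC(=O)CC(=O)N1CCSC1COc1ccccc1O`) gives 20 mg/kg and so stands beyond the scatter, with a lower number than compound 2. Compound 4 (`COc1ccccc1OCC1SCCN1C(=O)CC(=O)O`) differs from compound 2 by carboxy in place of hydrogen on a saturated chain carbon bound to a carbonyl carbon in the form of carboxy in place of hydrogen on a saturated chain carbon bound to a carbonyl carbon. Among the measured compounds shown here, no measured step isolates this change. The expectation leans on compound 3 at 20 mg/kg as a compound that also carries a further carbonyl in its chain. In this assay a small move toward a lower number is expected, possibly none beyond the scatter. The estimated step of a 1.3-fold lower number from compound 2 to compound 4 (0.12 log units; within the scatter) stays modest. Compound 4 is estimated at 35 mg/kg with an expected range from 12 mg/kg to 100 mg/kg in this measurement.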

Compound 4, dose for half-maximal effect: 20 mg/kg
For compound 4 the middle estimate is 1.8-fold (0.24 log units) above the measured one; measured number inside the range.
By their numbers in this assay, from the lowest: compounds 3 and 4 (each within the scatter of the next); then compounds 2 and 1 (each within the scatter of the next).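

In this assay, among the compounds shown here, carboxy in place of hydrogen on a saturated chain carbon bound to a carbonyl carbon gives a 2.3-fold lower number from compound 2 to compound 4 (0.36 log units; beyond the scatter), the first step here that isolates a single change. It shows that this position is not indifferent to substitution, since the acetyl of compound 2 becomes a (carboxymethyl)carbonyl and the effect appears at smaller amounts of compound. The data offer no measurement that explains this step. As far as these compounds go, whether an amine in place of the carboxy, or a longer chain carrying the carboxy, would give a similar step remains open.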